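A few compounds are considered here, and "the series" means these few. Any claim that something is new, unique, unknown or untested is made for them only; others in the source may bear on it.

Of the compounds shown here, three have been measured in an ADME assay on the whole organism (plasma, strain Sprague-Dawley) for pharmacokinetics, with Rattus norvegicus as the target, read by LC-MS, at a dose of 5 mg/kg by the intravenous route; a higher number here means more compound in the circulation at the dose given, a lower number less compound in the circulation.

Compound 1 `C=CC(=O)N1CC[C@H](N2C(=O)N(c3ccccc3)Cc3cnc(Nc4cccc(N5CCN(C)CC5)c4)nc32)C1` gives 746 ng.h/mL.
Compound 2 `C=CC(=O)N1CC[C@H](N2C(=O)N(c3ccccc3)Cc3cnc(Nc4ccc(N5CCN(C)CC5)c(OC)c4)nc32)C1` gives 949 ng.h/mL.
Compound 3 `C=CC(=O)N1CC[C@H](N2C(=O)N(c3ccccc3)Cc3cnc(Nc4ccc(N5CCN(C)CC5)c(C)c4)nc32)C1` gives 1640 ng.h/mL.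

Compound 1 has the smallest of the three numbers. Compound 2 lies within the usual scatter of it, so the two cannot be told apart, while compound 3 sits beyond that scatter. Among the measured compounds shown here, the only step between compounds that differ in one place is a 1.7-fold higher number from compound 2 to compound 3 (0.24 log units; within the scatter), a change at a different position and of a different kind.

Compound 4 `C=CC(=O)N1CC[C@H](N2C(=O)N(c3ccccc3)Cc3cnc(Nc4ccccc4)nc32)C1` is the next compound. It differs from compound 1 in one place: hydrogen in place of 4-methylpiperazin-1-yl on an aromatic carbon. For the measured compounds named here, no measured pair in this set removes this group or anything like it, so no step here bears directly on the change; the step from compound 2 to compound 3 gives only a sense of how much a small change on this ring can shift the number. The expectation is therefore a number near that of compound 1, with no step beyond the scatter, but with wide uncertainty, so that for compound 4 the expected step is a 1.0-fold higher number from compound 1 to compound 4 (0.00 log units; within the scatter). For compound 4 the estimated value in this assay is 750 ng.h/mL, expected to fall between 250 ng.h/mL and 2200 ng.h/mL.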

Compound 4, area under the concentration-time curve: 2030 ng.h/mL
For compound 4 the middle estimate is 2.7-fold (0.43 log units) below the measured one; low and high end bracket the measured number.
By their numbers in this assay, from the lowest: compounds 1, 2, 3 and 4 (each within the scatter of the next, the first and the last beyond it).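

In this assay, hydrogen in place of 4-methylpiperazin-1-yl on an aromatic carbon gives a 2.7-fold higher number from compound 1 to compound 4 (0.43 log units; beyond the scatter), the only step shown that lies beyond the scatter. The whole group can therefore leave this place without any loss in the number; here, its removal goes with more compound in the circulation, not less. No measurement shown accounts for this step.

This rests on a single pair, so it cannot yet be said whether the result depends on the whole group or on only one part of it. From the compounds shown here alone, whether a morpholine ring or a dimethylamino group at the same place would give a number nearer to compound 1 or to compound 4 stays open, as does whether removing the group from the ring of compound 2 or compound 3 would give a similar step.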